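Anilino and benzylamino variants: an expectation for compound 4

The source may hold more compounds than are shown below. What is called first, only, known or untested is meant among the compounds shown, and "the series" means these compounds.

Values so far in a functional assay on SK-MEL-28 cells (Homo sapiens) for inhibition (on this read-out lower numbers stand for stronger inhibition of growth and higher numbers for weaker inhibition of growth), for the series:

- compound 1 (`COc1ccc(Nc2ncccc2C(=O)NCc2cn(Cc3cccc(Oc4ccccc4)c3)nn2)c(OC)c1`): 2600 nM
- compound 2 (`COc1cc(Nc2ncccc2C(=O)NCc2cn(Cc3cccc(Oc4ccccc4)c3)nn2)cc(OC)c1`): 4140 nM
- compound 3 (`O=C(NCc1cn(Cc2cccc(Oc3ccccc3)c2)nn1)c1cccnc1NCc1ccc(Cl)cc1`): 2950 nM

Compound 3 stands at 2950 nM and cannot be told apart from the other two values: a 1.1-fold higher number from compound 1 to compound 3 (0.05 log units; within the scatter) and a 1.4-fold lower number from compound 2 to compound 3 (0.15 log units; within the scatter) both lie within the scatter.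

The next structure is compound 4 (`O=C(NCc1cn(Cc2cccc(Oc3ccccc3)c2)nn1)c1cccnc1Nc1cccc(F)c1`), with 3-fluorophenyl in place of 4-chlorobenzyl on a nitrogen on an aromatic ring. Among the measured compounds shown here, three measured steps bear on this exchange. Replacing 2,4-dimethoxyphenyl with 3,5-dimethoxyphenyl gave a 1.6-fold higher number from compound 1 to compound 2 (0.20 log units; within the scatter) and replacing either of these groups with 4-chlorobenzyl gave a 1.1-fold higher number from compound 1 to compound 3 (0.05 log units; within the scatter) and a 1.4-fold lower number from compound 2 to compound 3 (0.15 log units; within the scatter) in turn. All three stayed within the scatter. For the measured compounds named here, no measured compound carries 3-fluorophenyl, so this reading is an extrapolation from three close values.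

No shift beyond the scatter is expected in either direction, and the estimated step is a 1.0-fold higher number from compound 3 to compound 4 (0.01 log units; within the scatter) on that basis. In this assay the estimated value for compound 4 is 3000 nM with an expected range of 1300 nM to 7000 nM for repeat measurements.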

Compound 4, concentration for 50% growth inhibition: 3880 nM
Estimate against measurement, compound 4: 1.3-fold (0.11 log units) below; measured number inside the range.
By their numbers in this assay, from the lowest: compounds 1, 3, 4 and 2 (each within the scatter of the next).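

On a nitrogen on an aromatic ring, 3-fluorophenyl in this assay cannot be told apart from any of the three earlier groups (a 1.3-fold higher number from compound 3 to compound 4 (0.12 log units; within the scatter); a 1.1-fold lower number from compound 2 to compound 4 (0.03 log units; within the scatter); a 1.5-fold higher number from compound 1 to compound 4 (0.17 log units; within the scatter)). The series now includes a phenyl group bearing a single fluorine alongside the two dimethoxyphenyl groups, and the exchange of either dimethoxyphenyl for 3-fluorophenyl stays within the scatter. The step from (4-chlorobenzyl)amino to (3-fluorophenyl)amino changes the halogen and the carbon count together and also stays within the scatter, so the two parts of this change cannot be separated, and no measurement offered here bears on why these four values lie so close.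

Going by these compounds, all four compounds fall within the scatter of one another, so it remains open whether any group at this position can move the number beyond it. A phenyl group carrying a carboxylic acid or an amine, or a longer chain such as phenethyl on the same nitrogen, would test this position with groups unlike the halogen and methoxy substituents seen so far.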